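Nitro Replaced by Chloro: Expectation for Compound 3

The compounds below may be only part of what the source reports. "The series", "measured", "known", "first", "only" and "open" are said of these compounds alone.

Compound 1 `Cc1cc(O)c(C(C)C)cc1-c1cc(-c2ccco2)c(C#N)c(=O)[nH]1` gives 26% in a functional assay for inhibition, tested at 20 ug/mL; on this read-out higher numbers stand for a stronger effect at the one concentration tested and lower numbers for a weaker effect.
Compound 2 `Cc1cc(O)c(C(C)C)cc1-c1cc(-c2ccccc2[N+](=O)[O-])c(C#N)c(=O)[nH]1` gives 20% in this assay.

On these two numbers compound 2 stands lowest, and its nearest neighbour is compound 1, whose value sits a number 6 percentage points lower from compound 1 to compound 2 (within the scatter). Compound 3 `Cc1cc(O)c(C(C)C)cc1-c1cc(-c2ccccc2Cl)c(C#N)c(=O)[nH]1` has not yet been tested. It differs from compound 2 by chloro in place of nitro on an aromatic carbon.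

Among the measured compounds shown here, the only measured step, a number 6 percentage points lower from compound 1 to compound 2 (within the scatter), also changes the group at that same aromatic carbon, and it stayed within the scatter. For the measured compounds named here, a change of the group at that position, on the one example available, has moved the read-out in this assay by no more than the usual scatter. On that basis no step beyond the scatter is expected in either direction, so the step from compound 2 to compound 3 is expected to be a number 2 percentage points higher from compound 2 to compound 3 (within the scatter). Compound 3 is therefore estimated to give 22% in this assay, within a range of 8% to 38%.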

Compound 3, a percentage reported as inhibition, at one concentration (the size of the read-out at that concentration, not a potency): 12%
The estimate for compound 3 lay 10 percentage points above the measured number; low and high end bracket the measured number.
By their numbers in this assay, from the lowest: compounds 3, 2 and 1 (each within the scatter of the next, the first and the last beyond it).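

In this assay, chloro in place of nitro gives a number 8 percentage points lower from compound 2 to compound 3 (within the scatter) and so does not separate these two groups on the phenyl ring. Set against the furan-2-yl group, however, 2-chlorophenyl gives a number 14 percentage points lower from compound 1 to compound 3 (beyond the scatter) and is the first change at this aromatic carbon to pass beyond the scatter, although only modestly, while 2-nitrophenyl stays within the scatter of both neighbours. Nothing available explains this difference between the furan-2-yl and 2-chlorophenyl compounds.

The compounds shown leave open whether the step depends on the group on the phenyl ring or on the phenyl ring itself, which an unsubstituted phenyl group would help to separate. They also leave open how an amine or a carboxylic acid in place of chloro would read in this assay at this one concentration.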